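Swapping Pentyloxy for an Iodophenylamino Group

The compounds below may be only part of what the source reports. "The series", "measured", "known", "first", "only" and "open" are said of these compounds alone.

Of the compounds shown here, three built on one shared core have been tested in a functional assay on A549 cells (Homo sapiens) for antiproliferative activity, read by MTT assay, with a stated time of 72 h; a lower number here means a stronger inhibitor, a higher number a weaker inhibitor. Compound 1 `CCOC1=C(C(=O)c2ccccc2)C(c2ccc(Br)cc2)N(CCCn2ccnc2)C1=O` gives 35300 nM, compound 2 `CCCCCOC1=C(C(=O)c2ccccc2)C(c2ccc(Br)cc2)N(CCCn2ccnc2)C1=O` gives 7290 nM, and compound 3 `Cc1ccc(NC2=C(C(=O)c3ccccc3)C(c3ccc(Br)cc3)N(CCCn3ccnc3)C2=O)cc1` gives 29400 nM. Compound 2 stands lowest of the three numbers, and its distance to each neighbour lies beyond the usual scatter: the step of a 4.8-fold lower number from compound 1 to compound 2 (0.69 log units; beyond the scatter) and the step of a 4.0-fold higher number from compound 2 to compound 3 (0.61 log units; beyond the scatter) are both modest but real. The step of a 1.2-fold lower number from compound 1 to compound 3 (0.08 log units; within the scatter), by contrast, is within the scatter.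

Compound 4 `O=C(C1=C(Nc2ccc(I)cc2)C(=O)N(CCCn2ccnc2)C1c1ccc(Br)cc1)c1ccccc1` has not yet been measured. It differs from compound 2 in a single place: (4-iodophenyl)amino in place of pentyloxy on a double-bonded ring carbon. The step that bears most directly on this change is a 4.0-fold higher number from compound 2 to compound 3 (0.61 log units; beyond the scatter), since there too an arylamino group took the place of an alkoxy group on the same ring carbon. Compound 4 carries a (4-iodophenyl)amino group at that position, so a modest rise of similar size is expected, a 3.4-fold higher number from compound 2 to compound 4 (0.54 log units; beyond the scatter). Compound 4 is therefore estimated at 25000 nM, with a range from 8000 nM to 70000 nM.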

Compound 4, half-maximal inhibitory concentration: 24500 nM
Estimate against measurement, compound 4: 1.0-fold (0.01 log units) above; measured number inside the range.
By their numbers in this assay, from the lowest: compound 2; then compounds 4, 3 and 1 (each within the scatter of the next).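

The second arylamino group at this double-bonded ring carbon behaves like the first in this assay: replacing pentyloxy with (4-iodophenyl)amino gives a 3.4-fold higher number from compound 2 to compound 4 (0.53 log units; beyond the scatter), so the rise seen earlier is not confined to the methyl-bearing group. Swapping methyl for iodo on the aromatic ring produces a 1.2-fold lower number from compound 3 to compound 4 (0.08 log units; within the scatter), and replacing ethoxy with (4-iodophenyl)amino produces a 1.4-fold lower number from compound 1 to compound 4 (0.16 log units; within the scatter), so neither change separates the compounds it connects. No measurement shown explains these results, and the reason for them remains unknown.

Going by these compounds, it remains open whether a pentylamino group would track pentyloxy or the arylamino groups, which would help separate the effect of the chain from that of the linking atom. On these data alone, a longer chain such as heptyloxy also remains untested here, so it is unclear whether the trend from ethoxy to pentyloxy continues.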